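This account rests on a few compounds, and the source may have more. Where it says the series, first, only, none or still open, it means among the compounds named here.

Of the compounds shown here, three sharing one core have been tested in an assay on CHO cells for displacement of a labelled ligand from adenosine receptor A2b (Homo sapiens), read by scintillation counting, with a stated time of 75 min, in the presence of a further agent that is not named here; on this read-out lower numbers stand for stronger inhibition and higher numbers for weaker inhibition. Compound 1 `CCCn1c(=O)[nH]c2nc(-c3ccc(S(=O)(=O)N4CCN(c5ccc(F)cc5)CC4)cc3)[nH]c2c1=O` gives 0.644 nM, compound 2 `CCCn1c(=O)[nH]c2nc(-c3ccc(S(=O)(=O)N4CCN(c5cccc(Cl)c5)CC4)cc3)[nH]c2c1=O` gives 0.342 nM, and compound 3 `CCCn1c(=O)[nH]c2nc(-c3ccc(S(=O)(=O)N4CCN(c5ccccc5F)CC4)cc3)[nH]c2c1=O` gives 3.22 nM, the highest number of the three. The steps of a 5.0-fold higher number from compound 1 to compound 3 (0.70 log units; beyond the scatter) and a 9.4-fold higher number from compound 2 to compound 3 (0.97 log units; beyond the scatter) lie beyond the scatter, while the step of a 1.9-fold lower number from compound 1 to compound 2 (0.27 log units; within the scatter) does not. Compound 4 `CCCn1c(=O)[nH]c2nc(-c3ccc(S(=O)(=O)N4CCN(c5ccc(I)cc5)CC4)cc3)[nH]c2c1=O` is not yet measured; its change from compound 3 is 4-iodophenyl in place of 2-fluorophenyl on an amine nitrogen in a ring. Because the step of a 5.0-fold higher number from compound 1 to compound 3 (0.70 log units; beyond the scatter) shows that a 4-fluorophenyl group gives a lower number than a 2-fluorophenyl group, compound 4, which again carries a 4-substituted phenyl group, is expected to move back toward compound 1 and compound 2, with an expected step of a 6.4-fold lower number from compound 3 to compound 4 (0.81 log units; beyond the scatter). For compound 4 the estimated value is 0.5 nM, with a range from 0.15 nM to 1.8 nM.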

Compound 4, inhibition constant: 0.159 nM
For compound 4 the middle estimate is 3.1-fold (0.50 log units) above the measured one; the range from low to high includes it.
By their numbers in this assay, from the lowest: compound 4; then compounds 2 and 1 (each within the scatter of the next); then compound 3.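

In this assay, 4-iodophenyl in place of 2-fluorophenyl on the ring amine nitrogen gives a 20-fold lower number from compound 3 to compound 4 (1.31 log units; beyond the scatter), and it also improves on 3-chlorophenyl, with a 2.2-fold lower number from compound 2 to compound 4 (0.33 log units; beyond the scatter). Iodo in place of fluoro on the same aromatic carbon gives a 4.1-fold lower number from compound 1 to compound 4 (0.61 log units; beyond the scatter), so the identity of the halogen matters here, not only where it sits on the phenyl ring, and compound 4 has the lowest number of the four. Nothing available explains why iodo has this effect. On these data alone, what a methoxy group or a carboxylic acid on that same carbon would give remains open.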